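This account rests on a few compounds, and the source may have more. Where it says the series, first, only, none or still open, it means among the compounds named here.

Measured in a functional assay on Hep cells (Homo sapiens) for cytotoxicity, read by sulforhodamine B assay, with a stated time of 48 h; on this read-out lower numbers stand for stronger inhibition and higher numbers for weaker inhibition:
- Compound 1 `C=CCOc1ccc(F)cc1C(=O)c1cccnc1`: > 100000 nM
- Compound 2 `C=CCOc1c(Cl)cccc1C(=O)c1cccnc1`: 92000 nM
- Compound 3 `O=C(c1cccnc1)c1cc(Cl)ccc1O`: 27000 nM

Compound 1 reads > 100000 nM and this is a limit of the assay and not a number. Of the two true numbers, the higher belongs to compound 2, at 92000 nM. The nearest neighbour is compound 3 at 27000 nM, and the gap between the two lies beyond the scatter.

Compound 4 `O=C(c1cccnc1)c1cccc(Cl)c1O` has not yet been measured. It differs from compound 2 in one place: hydrogen in place of allyl on an oxygen on an aromatic ring. This puts hydrogen in place of allyl on an oxygen on an aromatic ring, which reads as allyloxy to hydroxy. Within the data shown here, no step between measured compounds shows this change on its own, so any forecast rests on thin ground. The closest guide is compound 3, which also carries a hydroxy and gives 27000 nM. On that single value, a drop to a lower number is expected in this assay, probably beyond the scatter but not a large one. The expected change is a 3.1-fold lower number from compound 2 to compound 4 (0.49 log units; beyond the scatter). For compound 4 the estimated value is 30000 nM, with an expected range of 11000 nM to 65000 nM.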

Compound 4, half-maximal inhibitory concentration: 28000 nM
The estimate for compound 4 lay 1.1-fold (0.03 log units) above the measured number; measured number inside the range.
By their numbers in this assay, from the lowest: compounds 3 and 4 (each within the scatter of the next); then compound 2. At a limit, above all of these: compound 1.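

In this assay, among these compounds, replacing allyl with hydrogen on an oxygen on an aromatic ring gives a 3.3-fold lower number from compound 2 to compound 4 (0.52 log units; beyond the scatter), the first direct reading of allyloxy to hydroxy. The earlier compounds shown here offered no pair that differed in this one place, so the effect of the change could not be separated from other differences in structure. The step is modest but beyond the scatter, and it shows that the allyl is not needed for a measurable number on this core, since compound 4, with its hydroxy, gives 28000 nM.

As far as these compounds go, compound 1 stands at a limit and not at a number, so it gives no size for this change on its own fluorine-bearing core: the limit of > 100000 nM in this assay, at which 1 of the 4 values shown sits. It also remains open whether the trend from allyloxy to hydroxy is specific to allyl or would extend to other groups on this oxygen, such as a methyl, a longer chain or a chain ending in an amine, and whether any of them would reach a much lower number in this assay.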